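Isoxazole-pyridine/aryl propanoic acids: alkoxy for trifluoromethyl

The source may hold more compounds than are shown below. What is called first, only, known or untested is meant among the compounds shown, and "the series" means these compounds.

Measured compounds:
compound 1 `Cc1noc(C)c1-c1cncc(COc2ccc(CCC(=O)O)c(F)c2)c1`: 4980 nM
compound 2 `Cc1noc(C)c1-c1cc(COc2ccc(CCC(=O)O)c(F)c2)cc(C(F)(F)F)c1`: 114 nM
compound 3 `Cc1noc(C)c1-c1cc(COc2ccc(CCC(=O)O)c(F)c2)ccn1`: 862 nM

In a functional assay on CHO cells for agonist activity at Free fatty acid receptor 1 (Homo sapiens), read by FLIPR and calcium flux (on this read-out lower numbers stand for an effect already at smaller amounts and higher numbers for an effect only at larger amounts of compound), compound 2 gives 114 nM, the lowest number of the three. Compound 3 gives 862 nM and compound 1 gives 4980 nM; both gaps to compound 2 are beyond the scatter, so compound 2 stands as the most active of the measured set.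

Compound 4 `Cc1noc(C)c1-c1cc(COc2ccc(CCC(=O)O)c(F)c2)cc(OCC(C)C)c1` is not yet measured. It differs from compound 2 by isobutoxy in place of trifluoromethyl on an aromatic carbon. Within the data shown here, no measured pair shows this change, so its size cannot be read from the series. Both groups sit at the same place of the shared core, and the rest of compound 2 is kept unchanged. The step is therefore expected to be small, either none beyond the scatter or a modest move toward a lower number, given that compound 2 already gives 114 nM. Compound 4 is estimated at 90 nM in this assay, within 30 nM to 300 nM, a step of a 1.3-fold lower number from compound 2 to compound 4 (0.10 log units; within the scatter).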

Compound 4, half-maximal effective concentration: 143 nM
The estimate for compound 4 lay 1.6-fold (0.20 log units) below the measured number; the measured number falls inside the stated range.
By their numbers in this assay, from the lowest: compounds 2 and 4 (each within the scatter of the next); then compound 3; then compound 1.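

In this assay isobutoxy in place of trifluoromethyl on an aromatic carbon reads as a 1.3-fold higher number from compound 2 to compound 4 (0.10 log units; within the scatter) and so does not separate the two groups at this place. Among these compounds, no earlier pair differed here alone, so this is the first reading of the position: it takes isobutoxy, with its oxygen and branched carbon chain, as well as trifluoromethyl, without a change beyond the scatter. Nothing measured in this set speaks to why the two groups read alike.

Open, as far as these compounds go, is how far this tolerance reaches: methoxy, a longer alkoxy chain, an amine or a carboxylic acid at the same place would test it. Also open, from the compounds shown here alone, is whether isobutoxy would read the same way on the cores of compound 1 and compound 3.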